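The source may report more compounds than this note shows. Statements on the series, on what has been measured and on what is new or still open speak of the compounds shown alone.

Measured so far in a functional assay on K562 cells (Homo sapiens) for antiproliferative activity, read by MTT assay, with a stated time of 48 h; a higher number here means a weaker inhibitor, a lower number a stronger inhibitor:
- compound 1 `Cn1cc(C2=C(c3nn(CCCn4ccnc4)c4ncccc34)C(=O)N(c3ccccc3)C2=O)c2ccccc21`: 5510 nM
- compound 2 `Cn1cc(C2=C(c3nn(CCCn4ccnc4)c4ncccc34)C(=O)NC2=O)c2ccccc21`: 13800 nM

For the measured compounds named here, compound 2 stands at the highest of the two numbers in this assay; the nearest measured neighbour is at a lower number, and the single known step reads a 2.5-fold higher number from compound 1 to compound 2 (0.40 log units; beyond the scatter), that is hydrogen in place of phenyl on an amide-type nitrogen in a ring. Compound 3 `Cn1cc(C2=C(c3nn(CCCO)c4ncccc34)C(=O)NC2=O)c2ccccc21` differs from compound 2 in one place only: hydroxy in place of 1H-imidazol-1-yl on a saturated chain carbon, three bonds along the chain from an aromatic nitrogen. Going by the values given here, the one step measured so far, a 2.5-fold higher number from compound 1 to compound 2 (0.40 log units; beyond the scatter), concerns the ring nitrogen of the shared core and not the chain on the aromatic nitrogen, so it does not bear on this change. Among the compounds with values here, no measured pair shows what replacing the five-membered aromatic ring at the end of the three-carbon chain by a hydroxy does here. In the absence of such a comparison, a step in this assay of about the size of the usual scatter is expected, a 1.2-fold higher number from compound 2 to compound 3 (0.06 log units; within the scatter), with no clear direction. Compound 3 is therefore estimated at 16000 nM in this assay, with a range from 5000 nM to 50000 nM.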

Compound 3, half-maximal inhibitory concentration: 85800 nM
Compound 3: middle estimate off by 5.4-fold (0.73 log units), on the low side, outside the stated range (above it).
By their numbers in this assay, from the lowest: compound 1; then compound 2; then compound 3.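

In this assay, the end of the chain on the aromatic nitrogen proves not to be a silent position: hydroxy in place of 1H-imidazol-1-yl gives a 6.2-fold higher number from compound 2 to compound 3 (0.79 log units; beyond the scatter), a step beyond the scatter. For the compounds shown here, the earlier step, a 2.5-fold higher number from compound 1 to compound 2 (0.40 log units; beyond the scatter), concerned only the ring nitrogen of the shared core, so this is the first reading showing that the group carried by the propyl chain also changes the number, and that 3-hydroxypropyl gives a higher number than 3-(1H-imidazol-1-yl)propyl on this core. No available evidence accounts for the step, so the result stands as an observation about these two compounds only.

The compounds shown do not tell whether a dimethylamino group, a morpholine ring or a carboxylic acid at the end of the propyl chain would read closer to compound 2 or to compound 3, nor what a longer chain carrying the 1H-imidazol-1-yl group would give. Also open, going by these compounds, is whether the same change gives a step of similar size on the core of compound 1, with phenyl on the ring nitrogen, as it is read here only with hydrogen at that nitrogen.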